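Dimethoxyphenyl in Place of Ethyl on the Ring Nitrogen

The compounds below may be only part of what the source reports. "The series", "measured", "known", "first", "only" and "open" are said of these compounds alone.

Compound 2 `CCN1C(=O)CSC1c1cccc(C(=O)NCCCCc2ccccc2)c1` stands lowest of the two measured numbers in a functional assay on U2OS cells (Homo sapiens) for inhibition, read by CCK-8 assay, with a stated time of 72 h, tested at 1 uM (on this read-out lower numbers stand for less inhibition and higher numbers for more inhibition at the one concentration tested (going by the name of the read-out)), giving 13%. Its nearest neighbour is compound 1 `O=C(NCCCCc1ccccc1)c1cccc(C2SCC(=O)N2c2ccccc2)c1`, which in this assay gives 68%. Within the data shown here, the one measured step, a number 55 percentage points lower from compound 1 to compound 2 (beyond the scatter), shows that exchanging the phenyl for ethyl on the amide-type nitrogen in the ring removed most of the inhibition.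

Compound 3 `COc1cccc(OC)c1N1C(=O)CSC1c1cccc(C(=O)NCCCCc2ccccc2)c1` has not yet been measured in this assay. It differs from compound 2 in a single place: 2,6-dimethoxyphenyl in place of ethyl on an amide-type nitrogen in a ring. The step from compound 1 to compound 2 bears directly on this change, as it also exchanged an aromatic ring for ethyl at the same nitrogen. Because a number 55 percentage points lower from compound 1 to compound 2 (beyond the scatter) was large, restoring an aromatic ring there is expected to raise the number in this assay considerably, though whether the two methoxy groups recover the full level of compound 1 cannot be told from the two compounds measured. Compound 3 is expected to give about 50% in this assay, within a range from 15% to 80%. This expectation corresponds to a step of a number 37 percentage points higher from compound 2 to compound 3 (beyond the scatter).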

Compound 3, a percentage reported as inhibition, at one concentration (the size of the read-out at that concentration, not a potency): 41%
Beside the measured number, compound 3's estimate is 9 percentage points above it; low and high end bracket the measured number.
By their numbers in this assay, from the lowest: compound 2; then compound 3; then compound 1.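

Across this assay, this position on the amide-type nitrogen in a ring now carries three different groups, and 2,6-dimethoxyphenyl in place of ethyl gives a number 28 percentage points higher from compound 2 to compound 3 (beyond the scatter) in a second comparison with ethyl at this nitrogen. The aromatic ring therefore stands above ethyl in both comparisons available, so the earlier drop seen with ethyl is not tied to plain phenyl alone. However, the substituted ring does not match the unsubstituted one, since 2,6-dimethoxyphenyl in place of phenyl gives a number 27 percentage points lower from compound 1 to compound 3 (beyond the scatter) and places compound 3 between the other two, apart from each of them beyond the scatter.

The three compounds cannot separate the contribution of the two methoxy groups from one another, and they leave open how a single methoxy group on the phenyl ring, a fluorine atom on that ring, a pyridine ring or a benzyl group at the same nitrogen would read in this assay on this shared core. Nothing is available here to explain why the three numbers differ.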